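The compounds below may be only part of what the source reports. "The series", "measured", "known", "first", "only" and "open" are said of these compounds alone.

Compound 1, `CNCc1cc(-c2ccccc2C)n(S(=O)(=O)c2ccc(C)cc2)c1`, gives 92%.
Compound 2, `CNCc1cc(-c2cccnc2F)n(S(=O)(=O)c2cccc(F)c2)c1`, gives 99%.
Compound 3, `CNCc1cc(-c2cccnc2F)n(S(=O)(=O)c2cccc(OC)c2)c1`, gives 92%.

All three numbers come from a functional assay on the whole organism (strain Jcl:SD) for inhibition, with Rattus norvegicus as the target, with stated times of 3 min and 3 h, at a dose of 1 mg/kg by the intravenous route; on this read-out lower numbers stand for less inhibition and higher numbers for more inhibition at the one dose given (going by the name of the read-out). Compound 3 stands level with compound 1 at the digits shown, the two together being the lowest of the three, and the only other step to it, a number 7 percentage points lower from compound 2 to compound 3 (within the scatter), lies within the scatter, so none of the three is set apart from the others.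

The unmeasured compound 4, `CNCc1cc(-c2cccnc2F)n(S(=O)(=O)c2cccs2)c1`, differs from compound 3 in one place: thiophen-2-yl in place of 3-methoxyphenyl on a sulfonyl sulfur. Among the compounds with values here, only one measured step touches the group on the sulfonyl sulfur, a number 7 percentage points lower from compound 2 to compound 3 (within the scatter), and that exchange of one group for another on the same ring stayed within the scatter. No measured step exchanges the ring itself, so the data give no reason to expect a shift beyond the scatter in this assay, and an expected step of a number 2 percentage points lower from compound 3 to compound 4 (within the scatter) follows. Compound 4 is therefore estimated at 90%, with a range from 75% to 99%.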

Compound 4, a percentage reported as inhibition, in the whole organism at one dose (the size of the read-out at that dose, not a potency): 96%
Compound 4: the middle estimate sits 6 percentage points below what was measured; measured number inside the range.
By their numbers in this assay, from the lowest: compounds 1, 3, 4 and 2 (each within the scatter of the next).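

In this assay, replacing the whole aromatic ring on the sulfonyl sulfur, rather than only a group on that ring, gives a number 4 percentage points higher from compound 3 to compound 4 (within the scatter). Measured against the 3-fluorophenyl compound, thiophen-2-yl gives a number 3 percentage points lower from compound 2 to compound 4 (within the scatter), so at this position a five-membered ring with a sulfur atom reads the same as either six-membered carbon ring within the scatter. No other measurement here bears on why the read-out stays the same across this exchange.

The compounds shown leave open whether the sulfonyl sulfur would carry a group with no aromatic ring, such as a butyl chain, or a ring bearing a carboxylic acid or an amine. With a single dose, they also cannot show whether these compounds would separate at lower doses.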